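Swapping a Ring for a Methyl on a Nitrile Core

The compounds below may be only part of what the source reports. "The series", "measured", "known", "first", "only" and "open" are said of these compounds alone.

Measured compounds:
- compound 1, `N#C[C@@]1(NC(=O)[C@@H](CC(=O)N2CCOCC2)CC2CCCCC2)CCN(C2CCCC2)C1`: "not determined" (no result reported)
- compound 2, `N#C[C@@]1(NC(=O)[C@@H](CC(=O)N2CCOCC2)CC2Cc3ccccc3C2)CCN(C2CCCCC2)C1`: 23.1 nM

In an assay on isolated protein for inhibition of cathepsin S (Homo sapiens) (a lower number here means tighter binding, a higher number weaker binding), compound 1 has no single number to stand on; its result is simply not known. Compound 2 in this assay gives 23.1 nM, but compound 2 differs from compound 1 at more than one place, so its value only shows the level one related compound reaches, not where compound 1 itself lies.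

The step examined here leads from compound 1 to compound 3, whose structure is `CN1CC[C@@](C#N)(NC(=O)[C@@H](CC(=O)N2CCOCC2)CC2CCCCC2)C1`. The change is methyl in place of cyclopentyl on an amine nitrogen in a ring — methyl in place of cyclopentyl on an amine nitrogen in a ring. Among the measured compounds shown here, no measured pair shows this change, so the size and direction of its effect rest on nothing measured. A shift beyond the usual scatter, in either direction, is plausible; a loss of some binding seems somewhat more likely than a gain.

Compound 3 is therefore expected to give about 100 nM in this assay, estimated to fall between 15 nM and 800 nM.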

Compound 3, dissociation constant: 161 nM
The estimate for compound 3 lay 1.6-fold (0.21 log units) below the measured number, within the range that was stated.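

In this assay, among the compounds shown here, compound 3 gives 161 nM while compound 1 has only "not determined" (no result reported) as its entry, so no step between these two compounds can be read. Going by these compounds, whether methyl in place of cyclopentyl on the ring amine nitrogen tightens binding, weakens it or leaves it unchanged stays open. No other information bears on this result.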